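Replacing the Amide Side Group in Compound 4

This account rests on a few compounds, and the source may have more. Where it says the series, first, only, none or still open, it means among the compounds named here.

In a functional assay on U-937 cells (Homo sapiens) for antiproliferative activity, read by MTT assay, with a stated time of 24 h (a higher number here means a weaker inhibitor, a lower number a stronger inhibitor), compound 1 `CCCCc1oc2ccccc2c1C(=O)c1ccc(OCC(=O)NC(C)C)cc1` gives 17500 nM. Compound 2 `CCCCNC(=O)COc1ccc(C(=O)c2c(CCCC)oc3ccccc23)cc1` gives 22800 nM, and compound 3 `CCCCc1oc2ccccc2c1C(=O)c1ccc(OCC(=O)N[C@H](C)c2ccccc2)cc1` gives 19800 nM. These three share one core and differ only in the group on an amide-type nitrogen. Compound 3 lies within the scatter of both the others, so the three cannot be ranked.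

Compound 4 `CCCCc1oc2ccccc2c1C(=O)c1ccc(OCCCC(=O)N2CCCC2)cc1` is a larger departure: 2-((pyrrolidin-1-yl)carbonyl)ethyl in place of (1-phenylethyl)carbamoyl on a saturated chain carbon bound to an oxygen on an aromatic ring. In words, 2-((pyrrolidin-1-yl)carbonyl)ethyl replaces (1-phenylethyl)carbamoyl on a saturated chain carbon bound to an oxygen on an aromatic ring.

The closest evidence comes from the swaps among butyl, isopropyl and 1-phenylethyl on that nitrogen. They gave a 1.3-fold higher number from compound 1 to compound 2 (0.11 log units; within the scatter), a 1.1-fold higher number from compound 1 to compound 3 (0.05 log units; within the scatter) and a 1.2-fold lower number from compound 2 to compound 3 (0.06 log units; within the scatter). None of these swaps tests the new group, so they are only a loose guide. No step beyond the scatter is therefore expected in this assay, and the range is kept wide.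

The expected step is a 1.0-fold higher number from compound 3 to compound 4 (0.00 log units; within the scatter). For compound 4 the estimated value is 20000 nM, with an expected range from 9000 nM to 45000 nM.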

Compound 4, half-maximal inhibitory concentration: 7500 nM
Beside the measured number, compound 4's estimate is 2.7-fold (0.43 log units) above it; the whole stated range lies above it.
By their numbers in this assay, from the lowest: compound 4; then compounds 1, 3 and 2 (each within the scatter of the next).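

In this assay, swapping butyl, isopropyl and 1-phenylethyl on the amide nitrogen gave no step beyond the scatter, but replacing the whole side group does, with a 2.6-fold lower number from compound 3 to compound 4 (0.42 log units; beyond the scatter). The steps against the other two compounds point the same way, a 3.0-fold lower number from compound 2 to compound 4 (0.48 log units; beyond the scatter) and a 2.3-fold lower number from compound 1 to compound 4 (0.37 log units; beyond the scatter), so this position can respond to a change, though only modestly here. Compound 4 is the only one of the four set apart from the rest, and its entering group, 2-((pyrrolidin-1-yl)carbonyl)ethyl, has no amide hydrogen.

That group changes the chain and the nitrogen substituent together, so the compounds shown cannot say which matters; a pyrrolidine amide on the shorter chain of compound 3, or a piperidine amide on the chain of compound 4, would separate them. Nothing measured here explains the lower number.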